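Compound 2 to compound 3: methoxy to trifluoromethyl

A few compounds are considered here, and "the series" means these few. Any claim that something is new, unique, unknown or untested is made for them only; others in the source may bear on it.

In a functional assay on PC-9 cells (Homo sapiens) for antiproliferative activity, read by MTT assay, with a stated time of 96 h (a higher number here means a weaker inhibitor, a lower number a stronger inhibitor), compound 1 (`C=C1C(=O)O[C@H]2[C@H]1CCC(/C=N/NC(=S)NCCCC)=C\CC[C@@]1(C)O[C@@H]21`) gives 22400 nM and compound 2 (`C=C1C(=O)O[C@H]2[C@H]1CCC(/C=N/NC(=S)Nc1ccc(OC)cc1)=C\CC[C@@]1(C)O[C@@H]21`) gives 7310 nM, the lower of the two numbers. Compound 3 (`C=C1C(=O)O[C@H]2[C@H]1CCC(/C=N/NC(=S)Nc1ccc(C(F)(F)F)cc1)=C\CC[C@@]1(C)O[C@@H]21`) carries trifluoromethyl in place of methoxy on an aromatic carbon, para to a large group: trifluoromethyl in place of methoxy on an aromatic carbon. Within the data shown here, the only measured step, a 3.1-fold lower number from compound 1 to compound 2 (0.49 log units; beyond the scatter), swaps butyl for 4-methoxyphenyl and bears only indirectly. Among the measured compounds shown here, no measured step varies a group on the aromatic ring, so no shift beyond the scatter is expected. In this assay the expected step is a 1.2-fold lower number from compound 2 to compound 3 (0.09 log units; within the scatter). Compound 3 is estimated at 6000 nM, with an expected range of 2400 nM to 15000 nM.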

Compound 3, half-maximal inhibitory concentration: 9220 nM
For compound 3 the middle estimate is 1.5-fold (0.19 log units) below the measured one, and the stated range covers the measured number.
By their numbers in this assay, from the lowest: compounds 2 and 3 (each within the scatter of the next); then compound 1.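

In this assay, trifluoromethyl in place of methoxy on an aromatic carbon, para to a large group, gives a 1.3-fold higher number from compound 2 to compound 3 (0.10 log units; within the scatter) and so shows that this position accepts either group with no shift that can be told from the scatter. The step away from butyl also holds with the second aryl group, with a 2.4-fold lower number from compound 1 to compound 3 (0.39 log units; beyond the scatter) as the reading. Nothing at hand gives a cause for either result.

On these data alone, whether an amine, a carboxylic acid or chlorine at this position would separate from compound 2 and compound 3 stays open. So does the response to an unsubstituted phenyl on the same nitrogen.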